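One Group Swapped on a Sulfonamide Nitrogen

A few compounds are considered here, and "the series" means these few. Any claim that something is new, unique, unknown or untested is made for them only; others in the source may bear on it.

In a physicochemical assay for lipophilicity, at pH 7.4 (on this read-out higher numbers stand for higher lipophilicity and lower numbers for lower lipophilicity), compound 2 `CC(C)CN(c1ccc(N(C)C)cc1)S(=O)(=O)c1ccc2c(c1)C(O)CC(C1CCOCC1)O2` gives 3.51, and compound 1 `CC(C)CN(c1cccc(F)c1)S(=O)(=O)c1ccc2c(c1)C(O)CC(C1CCOCC1)O2` gives 3.39. For the measured compounds named here, these are the only two numbers measured so far, and they lie within the usual scatter of each other, so compound 2 cannot be told apart from compound 1.

The next structure, compound 3 `CC(C)CN(C1CCc2ccc(F)cc21)S(=O)(=O)c1ccc2c(c1)C(O)CC(C1CCOCC1)O2`, carries 6-fluoro-2,3-dihydro-1H-inden-1-yl in place of 4-(dimethylamino)phenyl on a sulfonamide nitrogen. Going by the values given here, only one measured step bears on this change: a number 0.12 log units higher from compound 1 to compound 2 (within the scatter). There, one group containing a six-membered aromatic ring replaced another on the same nitrogen, and the step stayed inside the scatter. The entering group in compound 3 adds a five-membered non-aromatic ring, a difference that step never tested, which makes it only a loose guide.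

A small upward step is expected, a number 0.19 log units higher from compound 2 to compound 3 (within the scatter), although the data do not settle its direction. For compound 3 the estimated value in this assay is 3.7, with an expected range from 3.25 to 4.15.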

Compound 3, distribution coefficient: 3.94
Beside the measured number, compound 3's estimate is 0.24 log units below it; low and high end bracket the measured number.
By their numbers in this assay, from the lowest: compounds 1 and 2 (each within the scatter of the next); then compound 3.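

Replacing 4-(dimethylamino)phenyl with 6-fluoro-2,3-dihydro-1H-inden-1-yl on the sulfonamide nitrogen gives a number 0.43 log units higher from compound 2 to compound 3 (beyond the scatter) in this assay and replacing 3-fluorophenyl with the same group gives a number 0.55 log units higher from compound 1 to compound 3 (beyond the scatter) on the same read-out. For the compounds shown here, these modest steps are the first at this position to lie beyond the scatter, so the read-out can respond to a change on this nitrogen, even though the two compounds carrying a substituted phenyl group there could not be told apart. No supporting measurement explains the higher numbers, and the entering group differs from both leaving groups in more than one feature, including its five-membered non-aromatic ring.

On these data alone, it remains open how much of the rise goes with that five-membered ring and how much with the fluorine on the entering group, a question that an unsubstituted 2,3-dihydro-1H-inden-1-yl group or a cyclohexyl group on the same nitrogen would help to address. As far as these compounds go, it also remains open how this read-out would respond to an amine or a carboxylic acid on the entering group.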